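Replacing 3-methoxyphenyl with pyridin-3-yl at the assay limit

This account rests on a few compounds, and the source may have more. Where it says the series, first, only, none or still open, it means among the compounds named here.

Compound 1 `COc1cccc(NC(=O)Nc2ccc(Oc3ncnc4[nH]ncc34)cc2)c1`: > 10000 nM (a limit)
Compound 2 `COc1cccc(NC(=O)Nc2ccc(Oc3ncnc4c3cnn4C)cc2)c1`: > 10000 nM (a limit)

In a functional assay on HeLa cells (Homo sapiens) for inhibition, read by MTT assay, with a stated time of 72 h (on this read-out lower numbers stand for stronger inhibition and higher numbers for weaker inhibition), compound 1 stands only at a limit, > 10000 nM. Within the data shown here, the one measured step is a step that the two limits leave unreadable from compound 1 to compound 2, so it offers no size to carry over, and the whole evidence is the limit of > 10000 nM in this assay, at which 2 of the 2 values shown sit. Compound 3 `O=C(Nc1ccc(Oc2ncnc3[nH]ncc23)cc1)Nc1cccnc1` is still to be measured and differs from compound 1 as follows: pyridin-3-yl in place of 3-methoxyphenyl on an amide-type nitrogen. This places pyridin-3-yl in place of 3-methoxyphenyl on an amide-type nitrogen. No change beyond the scatter is expected in this assay, in either direction. The expected step is a step that the limit leaves unreadable from compound 1 to compound 3. Compound 3 is estimated at 15000 nM, within an expected range of 5000 nM to 50000 nM.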

Compound 3, half-maximal inhibitory concentration: > 10000 nM
Compound 3: a limit, no number (the forecaster's own chance of this, stated with the estimate: 80%); the middle value is on the limit's open side.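

Among these compounds, compound 3 stands at a limit, as do compound 1 and compound 2, so no step from compound 1 to compound 3 can be read: the limit of > 10000 nM in this assay, at which 3 of the 3 values shown sit.

In this assay the compounds shown leave open how strongly any of them inhibits, as none gives a number.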